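The compounds below may be only part of what the source reports. "The series", "measured", "known", "first", "only" and "open" are said of these compounds alone.

Working notes on the series. Among the measured compounds shown here, in an assay on membranes from HeLa cells for displacement of a labelled ligand from adenosine receptor A3 (Homo sapiens), read by scintillation counting, with a stated time of 180 min, tested at 1 uM (on this read-out lower numbers stand for less inhibition and higher numbers for more inhibition at the one concentration tested (going by the name of the read-out)), compound 2 `CCSC(=O)C1=C(C)NC(=O)NC1c1cccs1` gives 1%, the lowest of the two numbers measured, though within the scatter of its only neighbour: compound 1 `CCCC(=O)C1=C(C)NC(=O)NC1c1cccs1` gives 2% in this assay. For the measured compounds named here, the single measured step, a number 1 percentage points lower from compound 1 to compound 2 (within the scatter), is a change of the group on the carbonyl carbon and is within the scatter, so no shift beyond the scatter has yet been seen for changes at that place. Compound 3 `CC1=C(C(=O)OCC2CC2)C(c2cccs2)NC(=O)N1` differs from compound 2 by cyclopropylmethoxy in place of ethylsulfanyl on a carbonyl carbon. Going by the values given here, this bears on the step above only loosely, since cyclopropylmethoxy has not been measured here, but the one change at the carbonyl carbon, a number 1 percentage points lower from compound 1 to compound 2 (within the scatter), gave no step beyond the scatter, and both measured values are low. Compound 3 is therefore expected to show no step beyond the scatter in this assay, with a number 2 percentage points higher from compound 2 to compound 3 (within the scatter) as the estimated move. The estimate for compound 3 in this assay is 3%, ranging from -8% to 15%.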

Compound 3, a percentage reported as inhibition, at one concentration (the size of the read-out at that concentration, not a potency): 1%
Compound 3: the middle estimate sits 2 percentage points above what was measured; measured number inside the range.
By their numbers in this assay, from the lowest: compounds 2, 3 and 1 (each within the scatter of the next).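

In this assay, cyclopropylmethoxy in place of ethylsulfanyl on a carbonyl carbon gives no change at the digits printed from compound 2 to compound 3 (within the scatter) and, in place of propyl at the same carbon, gives a number 1 percentage points lower from compound 1 to compound 3 (within the scatter) as well. A group carrying a three-membered non-aromatic ring of carbon only, and with more heavy atoms than either group before it, therefore produces no step beyond the scatter at this place, so propyl, ethylsulfanyl and cyclopropylmethoxy cannot be told apart here. Nothing available accounts for this flat result.

The compounds shown leave open whether an amine or a carboxylic acid on this carbonyl carbon would produce a step beyond the scatter. With all three numbers low, they also leave open whether a change elsewhere on the shared core would do so.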